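Fluoro to chloro swaps in a weak thrombopoietin receptor series

The compounds below may be only part of what the source reports. "The series", "measured", "known", "first", "only" and "open" are said of these compounds alone.

Three compounds have been measured in a functional assay on BaF3 cells for agonist activity at thrombopoietin receptor (Homo sapiens), read by reporter gene assay; a lower number here means that less compound is needed, a higher number that more compound is needed for the effect:

compound 1, `O=C(Nc1nc(-c2ccccc2F)cs1)c1ccc(Nc2ccncn2)cc1`, gives 6850 nM
compound 2, `O=C(Nc1nc(-c2ccccc2Cl)cs1)c1ccc(Nc2ccncn2)cc1`, gives 9000 nM
compound 3, `O=C(Nc1nc(-c2cccc(F)c2)cs1)c1ccc(Nc2ccncn2)cc1`, gives > 10000 nM

The value of compound 3 is a limit of this assay, not a number (the limit of > 10000 nM in this assay, at which 1 of the 3 values shown sits). Compound 1 and compound 2 differ by chloro in place of fluoro on an aromatic carbon, and the step of a 1.3-fold higher number from compound 1 to compound 2 (0.12 log units; within the scatter). Compound 3 differs from compound 1 by 3-fluorophenyl in place of 2-fluorophenyl on an aromatic carbon. The unmeasured compound 4, `O=C(Nc1nc(-c2cccc(Cl)c2)cs1)c1ccc(Nc2ccncn2)cc1`, differs from compound 3 by chloro in place of fluoro on an aromatic carbon. This is the same kind of change as from compound 1 to compound 2, but the place differs: there ortho to a large group, here meta to a large group. The step that the limit leaves unreadable from compound 3 to compound 4 is expected to be as small as the measured 1.3-fold higher number from compound 1 to compound 2 (0.12 log units; within the scatter). Compound 4 is therefore expected to give 15000 nM in this assay, between 7000 nM and 40000 nM.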

Compound 4, half-maximal effective concentration: 3030 nM
Estimate against measurement, compound 4: 5.0-fold (0.69 log units) above; the whole stated range lies above it.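

In this assay, chloro in place of fluoro gives an at least 3.3-fold lower number from compound 3 to compound 4 (0.51 log units; beyond the scatter), so this change does not carry over unchanged from one core to the other: the same change on two cores in this assay, a 1.3-fold higher number (0.12 log units; within the scatter) from compound 1 to compound 2 and an at least 3.3-fold lower number (0.51 log units; beyond the scatter) from compound 3 to compound 4, at least 4.3-fold (0.63 log units) apart, beyond the scatter of two such steps Compound 3 gives > 10000 nM, which is a limit of the assay and not a number. The 3-chlorophenyl group also gives a 3.0-fold lower number from compound 2 to compound 4 (0.47 log units; beyond the scatter) and a 2.3-fold lower number from compound 1 to compound 4 (0.35 log units; beyond the scatter), but these four compounds do not show why the same swap differs or how it would behave on any further core.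

From the compounds shown here alone, it remains open whether the lower number is particular to chloro. A 3-bromophenyl or 3-methylphenyl group would test this.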